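Cytotoxicity notes: removing the two bromines from compound 1

The source may report more compounds than this note shows. Statements on the series, on what has been measured and on what is new or still open speak of the compounds shown alone.

Measured in an ADME assay on HEK293 cells (Homo sapiens) for cytotoxicity, read by reporter gene assay and resazurin assay, with a stated time of 48 h (on this read-out higher numbers stand for lower toxicity in this test and lower numbers for higher toxicity in this test), so far:
Compound 1, `O=C(Nc1ccc(Sc2nc3ccccc3s2)cc1)c1cc(Br)cc(Br)c1O`: 66000 nM.
Compound 2, `COc1c(Br)cc(Br)cc1C(=O)Nc1ccccc1`: > 100000 nM, which is a limit of the assay and not a number.
Compound 3, `O=C(Nc1ccccc1)c1cccc(Br)c1O`: 82000 nM.

Of the two numbers in this assay, compound 1 and compound 3 sit within the usual scatter of each other, so neither can be ranked against the other. The remaining value is a limit, as the line the limit of > 100000 nM in this assay, at which 1 of the 3 values shown sits, records, and gives no number to compare with.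

Compound 4, `O=C(Nc1ccc(Sc2nc3ccccc3s2)cc1)c1ccccc1O`, is not yet measured. Relative to compound 1 the change is 2-hydroxyphenyl in place of 3,5-dibromo-2-hydroxyphenyl on a carbonyl carbon. For the measured compounds named here, no measured pair in the set differs in just this way, so the size of the step has no direct precedent. The step from compound 1 to compound 4 is expected to be small, toward a higher number, a 1.3-fold higher number from compound 1 to compound 4 (0.11 log units; within the scatter), and may well fall within the scatter. Compound 4 is therefore estimated at 85000 nM, with a plausible range from 45000 nM to 160000 nM, and the assay may report only a limit.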

Compound 4, half-maximal cytotoxic concentration: 74000 nM
Beside the measured number, compound 4's estimate is 1.1-fold (0.06 log units) above it; the measured number falls inside the stated range.
By their numbers in this assay, from the lowest: compounds 1, 4 and 3 (each within the scatter of the next). At a limit, above all of these: compound 2.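

In this assay, for the compounds shown here, the only pair in the set that differs in one place gives a 1.1-fold higher number from compound 1 to compound 4 (0.05 log units; within the scatter). On the carbonyl carbon of the core of compound 1, 2-hydroxyphenyl and 3,5-dibromo-2-hydroxyphenyl therefore cannot be told apart on this read-out, so the two bromines are not shown to matter here. No measurement shown accounts for this outcome.

On these data alone, it remains open whether a group of another kind on this ring, such as an amine or a carboxylic acid in place of the hydroxyl, would move the number beyond the scatter. Also open, as far as these compounds go, is whether a single bromine on this ring, with the core of compound 1 held, would read any differently from compound 1 or compound 4.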